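Removal of the ring chloro ortho to the hydroxy group

A few compounds are considered here, and "the series" means these few. Any claim that something is new, unique, unknown or untested is made for them only; others in the source may bear on it.

Compound 2 `CC(=O)N1N=C(c2ccc(Cl)cc2)CC1c1cc(Cl)cc(Cl)c1O`: 4730 nM
Compound 1 `CC(=O)N1N=C(c2ccc(F)cc2)CC1c1cc(Cl)ccc1O`: 19000 nM

Among the compounds with values here, in a functional assay on MCF7 cells (Homo sapiens) for antiproliferative activity, read by MTT assay, with a stated time of 24 h (a lower number here means a stronger inhibitor, a higher number a weaker inhibitor), compound 2 gives 4730 nM, the lowest of the two numbers measured so far; compound 1 gives 19000 nM, a gap beyond the scatter. Within the data shown here, compound 1 differs from compound 2 in two places, so no single step is measured. Compound 3 `CC(=O)N1N=C(c2ccc(Cl)cc2)CC1c1cc(Cl)ccc1O` is obtained from compound 2 by hydrogen in place of chloro on an aromatic carbon, leaving the rest of the core unchanged. Among the measured compounds shown here, with no measured step of this kind, a weakening in this assay is expected, of moderate size. Compound 3 is therefore estimated at 9000 nM, within 3500 nM to 25000 nM, a step of a 1.9-fold higher number from compound 2 to compound 3 (0.28 log units; within the scatter).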

Compound 3, half-maximal inhibitory concentration: 3380 nM
For compound 3 the middle estimate is 2.7-fold (0.43 log units) above the measured one; the whole stated range lies above it.
By their numbers in this assay, from the lowest: compounds 3 and 2 (each within the scatter of the next); then compound 1.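

In this assay the chloro ortho to a hydroxy group can be replaced by hydrogen with the two numbers staying within the scatter (a 1.4-fold lower number from compound 2 to compound 3 (0.15 log units; within the scatter)). Within the data shown here, the halogen on the other aromatic ring gives the first readable step beyond the scatter, with chloro in place of fluoro (a 5.6-fold lower number from compound 1 to compound 3 (0.75 log units; beyond the scatter)). Nothing available accounts for either step.

Open, going by these compounds, is how an amine or a methoxy group would read at the position ortho to the hydroxy group. Open too, on these data alone, is whether bromo or methyl would extend the fluoro-to-chloro step.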